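Swapping the amide substituent at an inactive limit

The source may hold more compounds than are shown below. What is called first, only, known or untested is meant among the compounds shown, and "the series" means these compounds.

Compound 1 `C=CC1=C(C(=O)NCCC)C(c2ccc(OC)c(OC)c2)OC1` in a functional assay on SW480 cells (Homo sapiens) for cytotoxicity, read by MTT assay, with a stated time of 24 h; on this read-out lower numbers stand for stronger inhibition and higher numbers for weaker inhibition: compound 1 gives > 100000 nM, which is a limit of the assay rather than a number.
Compound 2 `C=CC1=C(C(=O)NCc2ccc(C)cc2)C(c2ccc(OC)cc2)OC1`: compound 2 gives 31700 nM.
Compound 3 `C=CC1=C(C(=O)NCc2ccc(C)cc2)C(c2ccc(F)cc2)OC1`: compound 3 gives > 100000 nM, again a limit of the assay rather than a number.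

Compound 3 therefore stands at the weak end of what is shown, with no number of its own. Among the measured compounds shown here, the one measured step that reaches it, an at least 3.1-fold higher number from compound 2 to compound 3 (0.49 log units; beyond the scatter), goes upward, and the observation the limit of > 100000 nM in this assay, at which 2 of the 3 values shown sit, notes that most of the values shown sit at that same limit.

Compound 4 `C=CC1=C(C(=O)NC2CCCCC2)C(c2ccc(F)cc2)OC1` is the next compound. Its structural change from compound 3 is cyclohexyl in place of 4-methylbenzyl on an amide-type nitrogen. No measured step alters the group on the amide-type nitrogen, so none bears directly on this change; the only step shown, an at least 3.1-fold higher number from compound 2 to compound 3 (0.49 log units; beyond the scatter), concerns the aromatic ring and ran toward weaker inhibition. With compound 3 already at the limit and no guidance from a comparable step, the expectation is that the step of a number no higher from compound 3 to compound 4 (the limit leaves the size open) stays within the scatter. Compound 4 is estimated at 100000 nM in this assay, with a range from 30000 nM to 300000 nM, most likely reported again as a limit.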

Compound 4, half-maximal inhibitory concentration: > 100000 nM
Compound 4 gave a limit, no number; the forecaster's own chance of this, stated with the estimate: 70%; the middle value sits exactly at the limit.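

Compound 3 and compound 4 both end at a limit of the assay rather than at a number, and no step can be read for cyclohexyl in place of 4-methylbenzyl on the amide-type nitrogen: the limit of > 100000 nM in this assay, at which 3 of the 4 values shown sit.
The compounds shown leave open whether the group on the amide-type nitrogen changes the result at all in this assay.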